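Acyl swap on the dodecyl amide: furan to isoquinoline

A few compounds are considered here, and "the series" means these few. Any claim that something is new, unique, unknown or untested is made for them only; others in the source may bear on it.

Three amides of the shared core have been measured in a functional assay on A-431 cells (Homo sapiens) for cytotoxicity, read by MTT assay, with a stated time of 48 h; on this read-out higher numbers stand for weaker inhibition and lower numbers for stronger inhibition. Compound 1 `CCCCCCCCNC(=O)[C@@H](NC(=O)c1ccco1)[C@@H](C)O` gives 64500 nM; compound 2 `C/C=C/C=C/C(=O)N[C@H](C(=O)NCCCCCCCC)[C@@H](C)O` gives 58200 nM; compound 3 `CCCCCCCCCCCCNC(=O)[C@@H](NC(=O)c1ccco1)[C@@H](C)O` gives 92400 nM, the highest of the three numbers, though within the scatter of both others. Compound 4 `CCCCCCCCCCCCNC(=O)[C@@H](NC(=O)c1nccc2ccccc12)[C@@H](C)O` differs from compound 3 by isoquinolin-1-yl in place of furan-2-yl on a carbonyl carbon. Going by the values given here, the one step at the same carbonyl carbon, a 1.1-fold lower number from compound 1 to compound 2 (0.04 log units; within the scatter), shows nothing beyond the scatter; the chain extension, a 1.4-fold higher number from compound 1 to compound 3 (0.16 log units; within the scatter), is likewise within it. Neither involves an isoquinolin-1-yl group, so no step beyond the scatter is expected here, a 1.2-fold lower number from compound 3 to compound 4 (0.06 log units; within the scatter) being the estimated outcome. For compound 4 in this assay the estimate is 80000 nM, between 30000 nM and 250000 nM.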

Compound 4, half-maximal inhibitory concentration: 62800 nM
Beside the measured number, compound 4's estimate is 1.3-fold (0.11 log units) above it; measured number inside the range.
By their numbers in this assay, from the lowest: compounds 2, 4, 1 and 3 (each within the scatter of the next).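

On the carbonyl carbon of the dodecyl amide, isoquinolin-1-yl in place of furan-2-yl gives a 1.5-fold lower number from compound 3 to compound 4 (0.17 log units; within the scatter) in this assay. Going by these compounds alone, this is the first change at this position to add a second aromatic ring and to exchange the ring oxygen for a ring nitrogen, and the step stays inside the scatter. Swapping furan-2-yl for penta-1,3-dien-1-yl on the octyl amide tested neither feature.

Open, on these data alone, is whether a carboxylic acid or an amine on the acyl ring would give a step beyond the scatter. Nothing available explains the result.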